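From a Phenoxy Cap to a Fluorinated Cyclopentyl Cap

The source may report more compounds than this note shows. Statements on the series, on what has been measured and on what is new or still open speak of the compounds shown alone.

Three compounds share one core and differ only in the group attached through an oxygen to a carbonyl carbon. Compound 1 `CC(C)(C)OC(=O)N1CCC(O[C@H]2CC[C@H](Oc3cnc(S(C)(=O)=O)cn3)CC2)CC1` carries a tert-butyl there, compound 2 `C[C@@H](CF)OC(=O)N1CCC(O[C@H]2CC[C@H](Oc3cnc(S(C)(=O)=O)cn3)CC2)CC1` a 1-(fluoromethyl)ethyl, and compound 3 `CS(=O)(=O)c1cnc(O[C@H]2CC[C@H](OC3CCN(C(=O)Oc4ccccc4)CC3)CC2)cn1` a phenyl. In a functional assay on isolated protein for agonist activity at Glucose-dependent insulinotropic receptor (Homo sapiens), read by HTRF and cAMP accumulation (on this read-out lower numbers stand for an effect already at smaller amounts and higher numbers for an effect only at larger amounts of compound), compound 1 gives 5.9 nM, compound 2 gives 31.1 nM, and compound 3 gives 9.6 nM. Compound 3 thus shows the second highest number of the three: the gap a 1.6-fold higher number from compound 1 to compound 3 (0.21 log units; within the scatter) is within the scatter, while a 3.2-fold lower number from compound 2 to compound 3 (0.51 log units; beyond the scatter) lies beyond it. The step of a 5.3-fold higher number from compound 1 to compound 2 (0.72 log units; beyond the scatter) marks the widest spread seen so far.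

Compound 4 `CS(=O)(=O)c1cnc(O[C@H]2CC[C@H](OC3CCN(C(=O)C4(C(F)(F)F)CCCC4)CC3)CC2)cn1` goes further: a group of 9 heavy atoms (6 carbon, 3 fluorine; one five-membered non-aromatic ring of carbon only) in place of a group of 7 heavy atoms (6 carbon, 1 oxygen; one six-membered aromatic ring of carbon only), on a carbonyl carbon. Among the compounds with values here, the entering group brings no oxygen, so the oxygen link that the three earlier caps shared is no longer present, and none of the measured steps covers this kind of change; they only show that varying the cap shifts the number modestly. Compound 4 is therefore expected to remain in a similar region, with an estimated step of a 1.3-fold higher number from compound 3 to compound 4 (0.10 log units; within the scatter). The estimate for compound 4 is 12 nM, expected to fall between 3 nM and 50 nM.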

Compound 4, half-maximal effective concentration: 38.4 nM
Estimate against measurement, compound 4: 3.2-fold (0.51 log units) below; measured number inside the range.
By their numbers in this assay, from the lowest: compounds 1 and 3 (each within the scatter of the next); then compounds 2 and 4 (each within the scatter of the next).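

On the carbonyl carbon, the new cap with no oxygen link and a five-membered carbon ring carrying fluorine loses ground in this assay against the two lowest numbers, giving a 4.0-fold higher number from compound 3 to compound 4 (0.60 log units; beyond the scatter) and a 6.5-fold higher number from compound 1 to compound 4 (0.81 log units; beyond the scatter). Set against the 1-(fluoromethyl)ethyl cap, it gives a 1.2-fold higher number from compound 2 to compound 4 (0.09 log units; within the scatter), so a cap without the oxygen link lands at the same level as one that keeps it, and losing that link does not open a new range among these four compounds. No measurement here explains these shifts.

Still open, as far as these compounds go, is which part of the new cap matters: the missing oxygen link, the trifluoromethyl or the ring. A plain cyclopentyl on the carbonyl carbon, or a cyclopentyloxy cap, would help separate these parts.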